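Chloro to Fluoro at Two Places on an Aryl Ring

The source may hold more compounds than are shown below. What is called first, only, known or untested is meant among the compounds shown, and "the series" means these compounds.

Compound 1 `Clc1ccccc1-c1n[nH]cc1N1CCNCC1` and compound 2 `Clc1ccc(-c2n[nH]cc2N2CCNCC2)cc1` hold the same atoms joined differently; how their cores differ is not broken down here. In an assay on isolated protein for binding affinity to 5-hydroxytryptamine receptor 6 (Homo sapiens) (a higher number here means a weaker inhibitor, a lower number a stronger inhibitor), compound 1 reaches only the limit > 10000 nM. Compound 2 gives 75 nM in this assay. Compound 3 `Fc1ccccc1-c1n[nH]cc1N1CCNCC1` arises from compound 1 by fluoro in place of chloro on an aromatic carbon. In this assay compound 3 gives 713 nM, which is an at least 14-fold lower number from compound 1 to compound 3 (1.14 log units; beyond the scatter). Compound 4 `Fc1ccc(-c2n[nH]cc2N2CCNCC2)cc1` arises from compound 2 by the same kind of change, (fluoro in place of chloro on an aromatic carbon), yet the place differs: ortho to a large group in compound 3, para to a large group in compound 4. Among the measured compounds shown here, the earlier step began at the limit of > 10000 nM in this assay, at which 1 of the 3 values shown sits, so its true size is only a lower bound, and the para position has no measured precedent here. Compound 4 is expected to give 200 nM in this assay, between 50 nM and 800 nM. That amounts to an expected step of a 2.7-fold higher number from compound 2 to compound 4 (0.43 log units; beyond the scatter).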

Compound 4, inhibition constant: 373 nM
Compound 4: the middle estimate sits 1.9-fold (0.27 log units) below what was measured, and the stated range covers the measured number.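

In this assay, fluoro in place of chloro, para to a large group, gives a 5.0-fold higher number from compound 2 to compound 4 (0.70 log units; beyond the scatter), a modest step toward weaker binding. The same swap therefore does not carry over unchanged from one core to the other, and its direction even reverses: the same change on two cores in this assay, an at least 14-fold lower number (1.14 log units; beyond the scatter) from compound 1 to compound 3 and a 5.0-fold higher number (0.70 log units; beyond the scatter) from compound 2 to compound 4, at least 69-fold (1.84 log units) apart, beyond the scatter of two such steps With only two pairs, this sets no general rule for where the swap helps or harms, and the earlier step is only a lower bound, since compound 1 stands at a limit of the assay: the limit of > 10000 nM in this assay, at which 1 of the 4 values shown sits.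

Going by these compounds, it remains open how other groups at these two places, such as bromo, methyl, methoxy or trifluoromethyl, would fare in this assay. A plain hydrogen there would also show how much either halogen contributes.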